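Methyl for tert-butyl on the benzyl arm of compound 2

The source may hold more compounds than are shown below. What is called first, only, known or untested is meant among the compounds shown, and "the series" means these compounds.

Compound 2 `CC(C)(C)c1ccc(CN2C(=O)S/C(=C\c3ccc(N)cc3)C2=O)cc1` gives 80000 nM in a functional assay on FM3A cells (Mus musculus) for cytotoxicity, read by cell counting, with a stated time of 2 days (on this read-out lower numbers stand for stronger inhibition and higher numbers for weaker inhibition), the second highest of the three numbers recorded. Its nearest neighbour is compound 3 `CC(C)(C)c1ccc(CN2C(=O)S/C(=C\c3cccc(N)c3)C2=O)cc1`, which gives 188000 nM in this assay, reached by a 2.4-fold higher number from compound 2 to compound 3 (0.37 log units; beyond the scatter) through a 3-aminophenyl in place of a 4-aminophenyl. Far below both stands compound 1 `C=C(Br)C(=O)Nc1cccc(/C=C2\SC(=O)N(Cc3ccc(C)cc3)C2=O)c1`, which gives 1000 nM in this assay; it carries a methyl on its benzyl ring but differs from compound 2 in more than one place, so its number offers no isolated step.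

The unmeasured compound 4 `Cc1ccc(CN2C(=O)S/C(=C\c3ccc(N)cc3)C2=O)cc1` differs from compound 2 only in that (methyl in place of tert-butyl on an aromatic carbon). Among the compounds with values here, no measured step alters this group alone: the single step recorded, from compound 2 to compound 3, moves the amino group and says nothing about the benzyl substituent. Compound 4 is therefore expected to stay close to compound 2, with no change at the digits printed from compound 2 to compound 4 (within the scatter) as the estimated step, not beyond the scatter. Compound 4 is expected to give 80000 nM, with a range from 30000 nM to 200000 nM.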

Compound 4, half-maximal inhibitory concentration: > 250000 nM
Compound 4: a limit, no number; the forecaster's own chance of this, stated with the estimate: 10%; middle value at least 3.1-fold (0.49 log units) from the limit.
By their numbers in this assay, from the lowest: compound 1; then compound 2; then compound 3. At a limit, above all of these: compound 4.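

Within the data shown here, with methyl in place of tert-butyl, this assay records an at least 3.1-fold higher number from compound 2 to compound 4 (0.49 log units; beyond the scatter) as the first step to touch this position, whereas the earlier step moved only the amino group. The substituent on this aromatic carbon is therefore not silent on this read-out, and here the tert-butyl compound is the one that stays on the side of stronger inhibition. Compound 4 gives no number but a limit of the assay: the limit of > 250000 nM in this assay, at which 1 of the 4 values shown sits.

The limit leaves the full size of the step open, and it also leaves open whether tert-butyl has the same effect when the ring carries a 3-aminophenyl in place of a 4-aminophenyl. Going by these compounds, it is equally open whether an ethyl, an isopropyl or a chlorine on this carbon would behave like tert-butyl or like methyl.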